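The source may hold more compounds than are shown below. What is called first, only, known or untested is meant among the compounds shown, and "the series" means these compounds.

In a functional assay on the whole organism for inhibition, with Mus musculus as the target, at a dose of 20 mg/kg by the intraperitoneal route (on this read-out higher numbers stand for an effect only at larger amounts of compound and lower numbers for an effect already at smaller amounts), compound 1 `COc1ccccc1N1CCN(CCCCNC(=O)c2nsc3ccccc23)CC1` gives 7.24 mg/kg and compound 3 `CN(CCCCN1CCC(C(=O)c2ccc(F)cc2)CC1)C(=O)c1nsc2ccccc12` gives 8.2 mg/kg. These two numbers lie within the usual scatter of each other, so compound 3 stands level with compound 1 among the results that are actual numbers. Compound 2 `COc1ccccc1N1CCN(CCCN(C)C(=O)c2nsc3ccccc23)CC1` gives only a limit, > 20 mg/kg.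

Compound 4 `CN(CCCCN1CCC(c2noc3cc(F)ccc23)CC1)C(=O)c1nsc2ccccc12` differs from compound 3 at one place, on a saturated ring carbon of the six-membered non-aromatic ring with 1 nitrogen: a group of 10 heavy atoms (7 carbon, 1 nitrogen, 1 oxygen, 1 fluorine; one five-membered aromatic ring with 2 hetero atoms, one six-membered aromatic ring of carbon only) in place of a group of 9 heavy atoms (7 carbon, 1 oxygen, 1 fluorine; one six-membered aromatic ring of carbon only), on a saturated ring carbon. The (4-fluorophenyl)carbonyl group goes, and a larger group with two fused-looking aromatic parts, one of them a five-membered aromatic ring with 2 hetero atoms, takes its place.

Among the measured compounds shown here, no measured pair tests this swap directly. The closest guide is that compound 1, at 7.24 mg/kg, carries a very different group from compound 3 at that end of the molecule, yet the two values stay within the scatter. A change beyond the scatter is therefore not expected, with at most a slight lean toward smaller doses. The expected step is a 1.4-fold lower number from compound 3 to compound 4 (0.14 log units; within the scatter). The estimate for compound 4 is 6 mg/kg, with an expected range from 2.5 mg/kg to 18 mg/kg.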

Compound 4, dose for half-maximal effect: 1.5 mg/kg
For compound 4 the middle estimate is 4.0-fold (0.60 log units) above the measured one; measured number below the stated range.
By their numbers in this assay, from the lowest: compound 4; then compounds 1 and 3 (each within the scatter of the next). At a limit, above all of these: compound 2.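

Among the compounds shown here, the step in this assay, a 5.5-fold lower number from compound 3 to compound 4 (0.74 log units; beyond the scatter), is the first one here between two compounds that differ in one place, and it shows that this saturated ring carbon of the six-membered non-aromatic ring with 1 nitrogen is not indifferent to what it carries. Replacing (4-fluorophenyl)carbonyl with the group holding a five-membered aromatic ring with 2 hetero atoms moves the result toward an effect at a smaller dose, and the move is large enough to stand clear of ordinary repeat variation. The rest of the molecule is the same in both compounds, so this change in the number belongs to the swap at this one carbon, though no measurement shown explains why the swap has this effect.

Because the two groups differ in several ways at once, this single pair cannot say which feature matters, and a plain phenyl group or a version of the entering group without its fluorine on the same carbon would help to separate them. As far as these compounds go, it also remains open whether the swap would give a similar step with a pentyl chain in the molecule.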